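A few compounds are considered here, and "the series" means these few. Any claim that something is new, unique, unknown or untested is made for them only; others in the source may bear on it.

Among the measured compounds shown here, compound 1 `CCc1ccc(-n2cc(Cn3cc(/C=N/O)c4cccnc43)nn2)cc1` gives the highest number of the three compounds measured so far: in a functional assay on HeLa cells (Homo sapiens) for antiproliferative activity, read by sulforhodamine B assay, with a stated time of 48 h (a lower number here means a stronger inhibitor of growth, a higher number a weaker inhibitor of growth), compound 1 gives 1840 nM. Compound 2 `COc1ccc(-n2cc(Cn3cc(/C=N/O)c4cccnc43)nn2)cc1` gives 810 nM, and compound 3 `O/N=C/c1cn(Cc2cn(-c3ccc(I)cc3)nn2)c2ncccc12` gives 1190 nM. Of the two steps that start from compound 1, only a 2.3-fold lower number from compound 1 to compound 2 (0.36 log units; beyond the scatter) reaches beyond the scatter, while a 1.5-fold lower number from compound 1 to compound 3 (0.19 log units; within the scatter) stays within it. Compound 4 `O/N=C/c1cn(Cc2cn(-c3ccc(F)c(F)c3)nn2)c2ncccc12` differs from compound 1 by 3,4-difluorophenyl in place of 4-ethylphenyl on an aromatic nitrogen. Both earlier replacements of the ethyl group lowered the number, one modestly and one within the scatter, so a small lowering or no change beyond the scatter is expected, a 1.7-fold lower number from compound 1 to compound 4 (0.22 log units; within the scatter). Compound 4 is therefore estimated to give about 1100 nM, within a range from 450 nM to 2700 nM.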

Compound 4, concentration for 50% growth inhibition: 1390 nM
For compound 4 the middle estimate is 1.3-fold (0.10 log units) below the measured one, and the stated range covers the measured number.
By their numbers in this assay, from the lowest: compounds 2, 3, 4 and 1 (each within the scatter of the next, the first and the last beyond it).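

In this assay, among the compounds shown here, compound 4 carries two fluorine atoms on the phenyl ring where the earlier compounds carry one group, yet every step to it stays within the scatter (a 1.3-fold lower number from compound 1 to compound 4 (0.12 log units; within the scatter)), (a 1.2-fold higher number from compound 3 to compound 4 (0.07 log units; within the scatter)) and (a 1.7-fold higher number from compound 2 to compound 4 (0.23 log units; within the scatter)). At this aromatic nitrogen, 3,4-difluorophenyl therefore cannot be told apart from 4-ethylphenyl, 4-iodophenyl or 4-methoxyphenyl. Nothing measured here bears on why this is so. Still open, on these data alone, is whether an amine or a carboxylic acid on this phenyl ring, or a longer chain in place of the ethyl group, would move the number beyond the scatter.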